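Methyl added to the bromophenyl ring of compound 3

The source may hold more compounds than are shown below. What is called first, only, known or untested is meant among the compounds shown, and "the series" means these compounds.

Compound 1 `CCCN(c1nccc(-c2c(OC)cc(OC)cc2OC)n1)C(C1CC1)C1CC1`: 15 nM
Compound 2 `CCCN(c1nccc(-c2c(OC)cc(OC)cc2OC)n1)C1(c2ccoc2)CC1`: 700 nM
Compound 3 `CCCN(c1ncc(C)c(-c2ccc(Br)cc2)n1)C(C1CC1)C1CC1`: 49 nM

In an assay on CHO cells for displacement of a labelled ligand from corticotropin-releasing factor receptor 1 (Homo sapiens) (a lower number here means a stronger inhibitor, a higher number a weaker inhibitor), compound 3 gives 49 nM, the second highest of the three numbers; compound 1 sits lower at 15 nM and compound 2 higher at 700 nM. Compound 4 `CCCN(c1ncc(C)c(-c2ccc(Br)cc2C)n1)C(C1CC1)C1CC1` is not yet measured. The change is methyl in place of hydrogen on an aromatic carbon. Among the compounds with values here, the one measured step, a 47-fold higher number from compound 1 to compound 2 (1.67 log units; beyond the scatter), concerns the group on the nitrogen, not the aryl ring, so no measured step bears directly on this change. The data give no ground for a step beyond the scatter in this assay, so the expected step of a 1.2-fold lower number from compound 3 to compound 4 (0.09 log units; within the scatter) is small. Compound 4 is therefore estimated at 40 nM, with a range from 15 nM to 120 nM.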

Compound 4, inhibition constant: 63 nM
The estimate for compound 4 lay 1.6-fold (0.20 log units) below the measured number, within the range that was stated.
By their numbers in this assay, from the lowest: compound 1; then compounds 3 and 4 (each within the scatter of the next); then compound 2.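

In this assay, within the data shown here, methyl in place of hydrogen on an aromatic carbon, ortho to a large group and meta to a bromo group, gives the first readable step on this aryl ring, and it stays within the scatter (a 1.3-fold higher number from compound 3 to compound 4 (0.11 log units; within the scatter)). For this one pair, then, 4-bromophenyl to 4-bromo-2-methylphenyl leaves the number effectively unchanged. Nothing shown here explains this result.

From the compounds shown here alone, whether an amine or a carboxylic acid at this place would also leave the number unchanged stays open. So does whether a longer chain, such as propyl, would.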